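The compounds below may be only part of what the source reports. "The series", "measured", "known", "first", "only" and "open" are said of these compounds alone.

Measured so far:
compound 1 `C/C(=N\OCc1ccncc1)c1ccc(Sc2cc(F)cc(C3CCOCC3)c2)cc1` — 300 nM
compound 2 `CO[C@]1(c2cc(F)cc(Sc3ccc(/C(C)=N/OCC#N)cc3)c2)CCO[C@@H](C)C1` — 40 nM

In a functional assay (blood) for inhibition, with Homo sapiens as the target (a lower number here means a stronger inhibitor, a higher number a weaker inhibitor), compound 1 gives 300 nM and stands as the higher of the two numbers, while compound 2 gives 40 nM, a gap beyond the scatter. Compound 3 `C/C(=N\OCCSc1nnc(C)s1)c1ccc(Sc2cc(F)cc(C3CCOCC3)c2)cc1` keeps the core of compound 1 and differs only in the oxime ether substituent: ((5-methyl-1,3,4-thiadiazol-2-yl)sulfanyl)methyl in place of pyridin-4-yl on a saturated chain carbon bound to an oxygen. Going by the values given here, no measured pair shows this change, so no step for it is known. For compound 3 no step beyond the scatter is expected in this assay. The estimated step is no change at the digits printed from compound 1 to compound 3 (within the scatter). Compound 3 is thus expected to give 300 nM, within a range of 100 nM to 1000 nM.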

Compound 3, half-maximal inhibitory concentration: 230 nM
For compound 3 the middle estimate is 1.3-fold (0.12 log units) above the measured one; low and high end bracket the measured number.
By their numbers in this assay, from the lowest: compound 2; then compounds 3 and 1 (each within the scatter of the next).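

In this assay, ((5-methyl-1,3,4-thiadiazol-2-yl)sulfanyl)methyl in place of pyridin-4-yl on a saturated chain carbon bound to an oxygen gives a 1.3-fold lower number from compound 1 to compound 3 (0.12 log units; within the scatter). On the core of compound 1, this position therefore accepts a five-membered aromatic ring with 3 hetero atoms in place of a six-membered one with 1, without a step beyond the scatter. No evidence bears on this result.

From the compounds shown here alone, whether an amine or a carboxylic acid at this place would give a step beyond the scatter remains open. The contributions of the sulfanyl link and the ring also cannot be separated.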